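This account rests on a few compounds, and the source may have more. Where it says the series, first, only, none or still open, it means among the compounds named here.

Working notes on the series. Among the measured compounds shown here, compound 1 `C=C1C(=O)[C@]23C[C@@]1(O)CC[C@H]2c1ccc(O)c(C)c1[C@@H]3Cn1cc(-c2ccccc2)nn1` is the one member with a number: in a functional assay on HL-60 cells (Homo sapiens) for cytotoxicity, read by MTT assay, with a stated time of 4 days (a higher number here means a weaker inhibitor, a lower number a stronger inhibitor), compound 1 gives 750 nM. Compound 2 `C=C1C[C@]23C[C@@]1(O)CC[C@@H]2c1cccc(C)c1[C@@H]3Cn1cc(-c2ccc(Cl)cc2)nn1` differs from compound 1 in several places, so the pair is not read as a single step. In this assay compound 2 gives > 20000 nM, which is a limit and not a number. Where compound 2 stands is therefore fixed only by the limit of > 20000 nM in this assay, at which 1 of the 2 values shown sits. Compound 3 `C=C1C[C@]23C[C@@]1(O)CC[C@@H]2c1cccc(C)c1[C@@H]3Cn1cc(-c2ccc(C)cc2)nn1` is not yet measured. The change from compound 2 to compound 3 is methyl in place of chloro on an aromatic carbon; cut one bond further out it reads 4-chlorophenyl to 4-methylphenyl. For the measured compounds named here, no step between measured compounds is known, and since compound 2 sits at a limit, no measured size can be attached to this change. The expected step is a step that the limit leaves unreadable from compound 2 to compound 3, none beyond the scatter. Compound 3 is expected at 25000 nM, with a range from 7000 nM to 90000 nM, most likely again reported only as a limit.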

Compound 3, half-maximal inhibitory concentration: > 20000 nM
Compound 3 ended at the assay's limit; the forecaster's own chance of this, stated with the estimate: 70%; the middle value does not contradict the limit.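

Compound 2 and compound 3 both stand at a limit and not at a number, so no step can be read for 4-chlorophenyl to 4-methylphenyl: the limit of > 20000 nM in this assay, at which 2 of the 3 values shown sit.

Still open, from the compounds shown here alone, is which of the several differences between compound 1 and compound 2 bears on the read-out.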